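The source may hold more compounds than are shown below. What is called first, only, known or untested is meant among the compounds shown, and "the series" means these compounds.

Measured so far:
compound 1, `CCCCC#Cc1nc(NCc2cccc(Br)c2)c2ncn([C@H]3[C@H](O)[C@H](O)[C@@H]4C[C@@H]43)c2n1` — 8.6 nM
compound 2, `CCCCC#Cc1nc(NC2CCCC2)c2ncn([C@H]3[C@H](O)[C@H](O)[C@@H]4C[C@@H]43)c2n1` — 160 nM

In an assay on CHO cells for displacement of a labelled ligand from adenosine receptor A3 (Homo sapiens), with a stated time of 60 min (a higher number here means a weaker inhibitor, a lower number a stronger inhibitor), compound 1 gives 8.6 nM, while compound 2 gives 160 nM, the higher of the two numbers. Among the measured compounds shown here, the one measured step, a 19-fold higher number from compound 1 to compound 2 (1.27 log units; beyond the scatter), is large. Compound 3, `CCCCC#Cc1nc(NC)c2ncn([C@H]3[C@H](O)[C@H](O)[C@@H]4C[C@@H]43)c2n1`, differs from compound 2 by methyl in place of cyclopentyl on a nitrogen on an aromatic ring. For the measured compounds named here, no measured step covers this exact change, so the direction rests on compound 2 alone and its value 160 nM. A step near compound 2 is expected, a 1.6-fold lower number from compound 2 to compound 3 (0.20 log units; within the scatter), not clearly beyond the scatter. Compound 3 is estimated at 100 nM, between 20 nM and 500 nM.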

Compound 3, inhibition constant: 4.9 nM
For compound 3 the middle estimate is 20-fold (1.31 log units) above the measured one; measured number below the stated range.
By their numbers in this assay, from the lowest: compounds 3 and 1 (each within the scatter of the next); then compound 2.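

In this assay, methyl on this nitrogen gives a 33-fold lower number from compound 2 to compound 3 (1.51 log units; beyond the scatter), so the loss seen with cyclopentyl does not simply reflect the absence of the 3-bromobenzyl group. Hydrogen in place of 3-bromophenyl gives a 1.8-fold lower number from compound 1 to compound 3 (0.24 log units; within the scatter), so among these compounds the bromine-bearing aromatic ring is not needed for a low number. Nothing measured here explains why cyclopentyl stands apart. Still open, from the compounds shown here alone, is how an ethyl group, a longer chain or an unsubstituted amine on this nitrogen would compare with methyl and cyclopentyl.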